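Chlorine added between two ring nitrogens of a fused core

The source may hold more compounds than are shown below. What is called first, only, known or untested is meant among the compounds shown, and "the series" means these compounds.

In a functional assay on DU-145 cells (Homo sapiens) for cytotoxicity, read by sulforhodamine B assay, with a stated time of 48 h (a lower number here means that less compound is tolerated, a higher number that more compound is tolerated), the three measured compounds stand as follows:
Compound 1 `ClCc1ccccc1Cn1cnc2c(Cl)nc(Cl)nc21` gives 6310 nM.
Compound 2 `ClCc1cccc(Cn2cnc3c(Cl)nc(Cl)nc32)c1` gives 5620 nM.
Compound 3 `ClCc1ccccc1Cn1cnc2ncnc(Cl)c21` gives 33100 nM.

Compound 3 thus has the highest number of the three in this assay; the nearest is compound 1 and the furthest compound 2, and both gaps lie beyond the usual scatter, so compound 3 is the most tolerated of the three. Compound 3 carries a single chloro on its core, whereas compounds 1 and 2 each carry two.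

Compound 4 `ClCc1ccccc1Cn1cnc2nc(Cl)nc(Cl)c21` is not yet measured. It differs from compound 3 by chloro in place of hydrogen on an aromatic carbon. Among the compounds with values here, no measured pair isolates this single change, so the step can only be judged from the two dichloro compounds. Because compound 1 gives 6310 nM and compound 2 gives 5620 nM, a second chloro appears to go with a lower number, although their core substitution pattern also differs from that of compounds 3 and 4. The step from compound 3 to compound 4 is therefore expected to be a 2.8-fold lower number from compound 3 to compound 4 (0.44 log units; beyond the scatter), a decrease of moderate size. Compound 4 is estimated at 12000 nM, with a range from 4000 nM to 35000 nM.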

Compound 4, concentration lethal to 50% of the cells: 7240 nM
The estimate for compound 4 lay 1.7-fold (0.22 log units) above the measured number, and the stated range covers the measured number.
By their numbers in this assay, from the lowest: compounds 2, 1 and 4 (each within the scatter of the next); then compound 3.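

In this assay, within the data shown here, this pair gives the first direct reading of the position between two ring nitrogen atoms: chloro in place of hydrogen on this aromatic carbon brings a 4.6-fold lower number from compound 3 to compound 4 (0.66 log units; beyond the scatter) and so counts as a modest step beyond the scatter. The earlier compounds shown here could not show this, as no two of them differed in one place, so the link between a second chloro and a lower number now rests on a matched pair, though only on this one. No measurement available here accounts for the size or direction of the step.

Going by these compounds, whether an amine, a methoxy group or a methyl group at this position would give a number near that of compound 3 or compound 4 remains open. So does whether the same change would give a similar step on the core of compound 2.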